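Nitroimidazole ethers on breast cancer cells: chloro to methyl

The compounds below may be only part of what the source reports. "The series", "measured", "known", "first", "only" and "open" are said of these compounds alone.

Measured compounds:
compound 1 `Cc1ncc([N+](=O)[O-])n1CCOc1ccc(F)cc1` — 85.8 ug/mL
compound 2 `Cc1ncc([N+](=O)[O-])n1CCOc1ccc(Cl)c(Cl)c1` — 69.7 ug/mL

The read-out is a functional assay on MCF7 cells (Homo sapiens) for cytotoxicity, read by MTT assay, with a stated time of 24 h; on this read-out lower numbers stand for stronger inhibition and higher numbers for weaker inhibition. Compound 1 gives 85.8 ug/mL in this assay, and compound 2 gives 69.7 ug/mL. Compound 2 carries the lowest of the two numbers, but its nearest neighbour, compound 1, sits within the scatter of it, so the two values show no difference that can be read as real. Within the data shown here, no pair differing in one place has been measured, so no step size is known for this series.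

Compound 3 `Cc1cc(OCCn2c([N+](=O)[O-])cnc2C)ccc1Cl` is not yet measured. It is obtained from compound 2 by the change (methyl in place of chloro on an aromatic carbon). Among the measured compounds shown here, the two measured values lie close together and give no hint how this assay answers a change of this kind; the only guide is that both numbers fall in a narrow band. The step from compound 2 to compound 3 is therefore expected to stay within the scatter, in no definite direction, with a 1.1-fold higher number from compound 2 to compound 3 (0.03 log units; within the scatter) as the estimated step. For compound 3 the expected value is 75 ug/mL, with a range from 40 ug/mL to 140 ug/mL.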

Compound 3, half-maximal inhibitory concentration: 188 ug/mL
Compound 3: middle estimate off by 2.5-fold (0.40 log units), on the low side; measured number outside the range, above it.
By their numbers in this assay, from the lowest: compounds 2 and 1 (each within the scatter of the next); then compound 3.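

In this assay, among these compounds, the change to methyl in place of chloro, on an aromatic carbon ortho to a chloro group and meta to a large group, gives a 2.7-fold higher number from compound 2 to compound 3 (0.43 log units; beyond the scatter) and so supplies the one step that lies beyond the scatter. This position therefore answers in the assay, even to an exchange of one heavy atom for one heavy atom, with no ring, hydrogen-bond donor, hydrogen-bond acceptor or net charge entering or leaving. Between these two groups at this carbon, chloro goes with the lower number and thus the stronger inhibition, while nothing on hand speaks to what lies behind the step.

Going by these compounds, whether this reflects something particular to chloro stays open, as a single pair cannot show how bromo, trifluoromethyl, methoxy or an amine would rank at the same carbon. Also open, on these data alone, is what the remaining chloro group contributes, and whether methyl in place of chloro on another aromatic carbon would give a step of similar size and direction.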